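The source may report more compounds than this note shows. Statements on the series, on what has been measured and on what is new or still open speak of the compounds shown alone.

Measured so far:
compound 1 `COc1cc(Cl)cc(-c2nn(-c3cccc(NC(=O)Nc4ccc(Cl)c(C(F)(F)F)c4)c3)cc2-c2ccncc2)c1`: 103%
compound 2 `COc1cc(Cl)cc(-c2nn(-c3cccc(NC(=O)Nc4cc(C(F)(F)F)cc(C(F)(F)F)c4)c3)cc2-c2ccncc2)c1`: 96%
compound 3 `COc1cc(Cl)cc(-c2nn(-c3cccc(NC(=O)Nc4ccc(Cl)c(Cl)c4)c3)cc2-c2ccncc2)c1`: 94%

In a functional assay on T47D cells (Homo sapiens) for inhibition, read by sulforhodamine B assay, with a stated time of 48 h, tested at 0.1 uM (a higher number here means a weaker effect of the compound at the concentration tested, a lower number a stronger effect), compound 3 gives 94%, the lowest of the three numbers, but compound 2 with 96% and compound 1 with 103% both lie within the scatter of it, so none of the three can be called stronger or weaker than another. Compound 4 `COc1cc(Cl)cc(-c2nn(-c3cccc(NC(=O)Nc4cccc(C(F)(F)F)c4)c3)cc2-c2ccncc2)c1` differs from compound 3 by 3-(trifluoromethyl)phenyl in place of 3,4-dichlorophenyl on an amide-type nitrogen. Among the compounds with values here, the one measured step touching this part of the molecule, a number 9 percentage points lower from compound 1 to compound 3 (within the scatter), stayed within the scatter. Since all three measured numbers sit near the level that means little effect at this concentration, a step beyond the scatter is not expected: compound 4 is estimated at 98% (range 88% to 108%), an expected step of a number 4 percentage points higher from compound 3 to compound 4 (within the scatter).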

Compound 4, a percentage reported as activity, at one concentration (the size of the read-out at that concentration, not a potency): 94%
Compound 4: middle estimate off by 4 percentage points, on the high side, and the stated range covers the measured number.
By their numbers in this assay, from the lowest: compounds 3, 4, 2 and 1 (each within the scatter of the next).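

In this assay, replacing 3,4-dichlorophenyl on the amide-type nitrogen with 3-(trifluoromethyl)phenyl gives no change at the digits printed from compound 3 to compound 4 (within the scatter). The single substituent on this ring also reads like either pair of substituents: losing one trifluoromethyl gives a number 2 percentage points lower from compound 2 to compound 4 (within the scatter), and losing the chloro gives a number 9 percentage points lower from compound 1 to compound 4 (within the scatter). No measurement shown explains why these changes leave the number within the scatter. On these data alone, whether an amine or a carboxylic acid on this ring would shift the number stays open. So does how these compounds compare at a higher concentration, where differences hidden here might appear.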